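The compounds below may be only part of what the source reports. "The series", "measured", "known", "first", "only" and "open" are said of these compounds alone.

Compound 1 `C=C[C@@](C)(/C=C/c1ccc(OC(=O)CCC)cc1)CCC=C(C)C` gives 41%
Compound 2 `C=C[C@@](C)(/C=C/c1ccc(OC(=O)CCCCCCCCCCCCCCC)cc1)CCC=C(C)C` gives 64%
Compound 3 `C=C[C@@](C)(/C=C/c1ccc(O)c([N+](=O)[O-])c1)CCC=C(C)C` gives 55%

In a functional assay on OVCAR-5 cells (Homo sapiens) for inhibition, with a stated time of 48 h, tested at 50 uM (a lower number here means less inhibition of growth, a higher number more inhibition of growth at the concentration tested), compound 3 stands at 55% and so lies within the scatter of compound 2 but beyond the scatter above compound 1. Compound 4 `C=C[C@@](C)(/C=C/c1ccc(O)c(N)c1)CCC=C(C)C` differs from it by one change: amino in place of nitro on an aromatic carbon, ortho to a hydroxy group (amino in place of nitro on an aromatic carbon). Among the measured compounds shown here, the only measured step is a number 23 percentage points higher from compound 1 to compound 2 (beyond the scatter) and it sits on a saturated chain elsewhere in the molecule. It shows that a single change can shift this read-out modestly, but it says nothing about this swap or its direction. No step beyond the scatter is therefore expected. The estimated step is a number 3 percentage points lower from compound 3 to compound 4 (within the scatter) and it stays small. For compound 4 the estimated value is 52% with an expected range from 33% to 70% for repeated measurements.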

Compound 4, percent growth inhibition at one concentration: 33%
The estimate for compound 4 lay 19 percentage points above the measured number; the measured number falls inside the stated range.
By their numbers in this assay, from the lowest: compounds 4 and 1 (each within the scatter of the next); then compounds 3 and 2 (each within the scatter of the next).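

In this assay the swap of nitro for amino, ortho to a hydroxy group, gives a number 22 percentage points lower from compound 3 to compound 4 (beyond the scatter) and so shows that the group on this aromatic carbon matters to growth inhibition. The earlier step lay on a saturated chain, so the read-out is now seen to respond to a change on the aromatic ring as well. Nothing measured here explains the drop.

From the compounds shown here alone, whether a carboxylic acid, a methoxy group or a fluorine atom on this carbon would land nearer compound 3 or compound 4 stays open. So does the role of the neighbouring hydroxy group in this step.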